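Antiproliferative series: phenyl in place of pyridin-4-yl

The source may hold more compounds than are shown below. What is called first, only, known or untested is meant among the compounds shown, and "the series" means these compounds.

Values so far in a functional assay on A2058 cells (Homo sapiens) for antiproliferative activity, read by luminescence and CellTiter-Glo, with a stated time of 96 h; on this read-out lower numbers stand for stronger inhibition and higher numbers for weaker inhibition
- compound 1 `COc1ccc(-c2ccc(F)c(C(=O)Nc3c[nH]nc3C(=O)Nc3ccc(F)cc3)c2F)cn1`: "not determined" (no result reported)
- compound 2 `O=C(Nc1ccc(F)cc1)c1n[nH]cc1NC(=O)c1c(F)ccc(-c2ccncc2)c1F`: 2940 nM

Within the data shown here, compound 2 at 2940 nM carries the only number, so it cannot yet be ranked against anything. Compound 1 has no result to compare with it.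

Compound 3 `O=C(Nc1ccc(F)cc1)c1n[nH]cc1NC(=O)c1c(F)ccc(-c2ccccc2)c1F` is not yet measured. It has phenyl in place of pyridin-4-yl on an aromatic carbon, ortho to a fluoro group and para to a fluoro group (phenyl in place of pyridin-4-yl on an aromatic carbon).

Among the measured compounds shown here, no step between measured compounds is available, so the expectation rests only on compound 2 at 2940 nM and on this one change, and neither direction is favoured. The expected change in this assay is a 1.0-fold lower number from compound 2 to compound 3 (0.01 log units; within the scatter) and nothing beyond the scatter is anticipated. Compound 3 is estimated at 2900 nM with an expected range of 800 nM to 10000 nM on this read-out.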

Compound 3, half-maximal inhibitory concentration: 2370 nM
Estimate against measurement, compound 3: 1.2-fold (0.09 log units) above; measured number inside the range.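

In this assay the exchange of pyridin-4-yl for phenyl gives a 1.2-fold lower number from compound 2 to compound 3 (0.09 log units; within the scatter), which lies within the scatter. On this aromatic carbon, ortho to a fluoro group and para to a fluoro group, the loss of the ring nitrogen and its hydrogen-bond acceptor therefore leaves the number effectively unchanged for this pair, and the two rings cannot be told apart on this read-out. No measurement is at hand that would explain this result.

The compounds shown leave open whether a morpholine, a carboxylic acid or an aminomethyl group on this carbon would move the number beyond the scatter. On these data alone, it is also open whether the same exchange would read the same way with a different group elsewhere on the shared core.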